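Replacing a Methoxyphenyl with a Hydroxyphenyl Hydrazone

A few compounds are considered here, and "the series" means these few. Any claim that something is new, unique, unknown or untested is made for them only; others in the source may bear on it.

Compound 1 `CCCSc1nc(N/N=C(\C)c2ccc(OC)cc2)c2nnn(Cc3ccccc3)c2n1` was tested in a functional assay on ECa-109 cells (Homo sapiens) for antiproliferative activity, read by MTT assay, with a stated time of 72 h; a higher number here means a weaker inhibitor, a lower number a stronger inhibitor. In this assay compound 1 gives only a limit, > 64000 nM, and no number. Compound 2 `CCCSc1nc(N/N=C/c2c[nH]c3ccccc23)c2nnn(Cc3ccccc3)c2n1` gives a measured value in this assay of 8690 nM. Compound 3 `CCCSc1nc(N/N=C(\C)c2ccccc2O)c2nnn(Cc3ccccc3)c2n1` carries 2-hydroxyphenyl in place of 4-methoxyphenyl on a carbon with a double bond to nitrogen. Among the compounds with values here, no measured pair shows this change, and a starting point that sits at the limit of > 64000 nM in this assay, at which 1 of the 2 values shown sits, leaves both the size and the direction of the step open. Compound 3 is nonetheless expected to land near 40000 nM, within 10000 nM to 128000 nM, an estimated step of an at least 1.6-fold lower number from compound 1 to compound 3 (0.20 log units; that floor lies within the scatter).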

Compound 3, half-maximal inhibitory concentration: 11100 nM
Beside the measured number, compound 3's estimate is 3.6-fold (0.56 log units) above it, and the stated range covers the measured number.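

With 2-hydroxyphenyl in place of 4-methoxyphenyl on a carbon with a double bond to nitrogen, this assay gives an at least 5.7-fold lower number from compound 1 to compound 3 (0.76 log units; beyond the scatter), so this position can respond to a change of group. Compound 1 gives only a limit, so this step is a floor and its full size stays unread: the limit of > 64000 nM in this assay, at which 1 of the 3 values shown sits.

The change alters both the group, methoxy to hydroxy, and its numbered place on the ring, and the compounds shown do not separate these two. A 4-hydroxyphenyl or a 2-methoxyphenyl group at this position would be needed to tell them apart.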